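This account rests on a few compounds, and the source may have more. Where it says the series, first, only, none or still open, it means among the compounds named here.

Compound 1, `CCN(CC)C(=O)CN(c1ccc(C)cc1)S(=O)(=O)c1ccc(OC)c(OC)c1`: in a functional assay on CHO cells for inhibition of Orexin/Hypocretin receptor type 1 (Homo sapiens), read by FLIPR and calcium flux (a lower number here means a stronger inhibitor, a higher number a weaker inhibitor), compound 1 gives > 10000 nM, a limit of the assay and not a number.
Compound 2, `CCN(CC)C(=O)CN(c1cc(N(CC)CC)ccc1Cl)S(=O)(=O)c1ccc(OC)c(OC)c1`: in this assay compound 2 gives > 10000 nM, likewise a limit.
Compound 3, `CCN(CC)C(=O)CN(c1ccc(C)cc1)S(=O)(=O)c1cccc(C)c1`: in this assay compound 3 gives > 10000 nM, likewise a limit.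

Compound 3 therefore stands at the limit of > 10000 nM in this assay, at which 3 of the 3 values shown sit. Since none of the three values is a number, nothing orders compound 3 against compound 1 or compound 2. Compound 4, `CCN(CC)C(=O)CN(c1ccc(C)cc1)S(=O)(=O)c1ccccc1F`, differs from compound 3 by 2-fluorophenyl in place of 3-methylphenyl on a sulfonyl sulfur. Going by the values given here, no step between measured compounds exists, so no size for such a change can be read from the data. Because compound 3 sits at the limit of > 10000 nM in this assay, at which 3 of the 3 values shown sit, compound 4 is expected to stay at or near that limit as well. The estimated step is a step that the limit leaves unreadable from compound 3 to compound 4, no change beyond the scatter in either direction. For compound 4 the expected value is 15000 nM, within a range from 3000 nM to 60000 nM.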

Compound 4, half-maximal inhibitory concentration: > 10000 nM
Compound 4: a limit, no number (the forecaster's own chance of this, stated with the estimate: 80%); the middle value is on the limit's open side.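

Going by these compounds alone, compound 3 and compound 4 both give a limit and not a number, so no step between them can be read. The compounds shown leave open which change, if any, would give a measurable value.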